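The source may report more compounds than this note shows. Statements on the series, on what has been measured and on what is new or still open speak of the compounds shown alone.

Measured compounds:
compound 1 `Cn1cc(C(=O)Nc2ccc(-c3ccccn3)c(C(F)(F)F)c2)c(=O)c2ccccc21` — 11 10^-6 cm/s
compound 2 `Cn1cc(C(=O)Nc2ccc(-c3ccccc3)c(C(F)(F)F)c2)c(=O)c2ncccc21` — 16 10^-6 cm/s
compound 3 `Cn1cc(C(=O)Nc2cc(C(F)(F)F)c(-c3ccccc3)cn2)c(=O)c2ccccc21` — < 1 10^-6 cm/s, a limit of the assay, not a number

In an ADME assay on LLC-PK1 cells (Sus scrofa) for permeability (on this read-out higher numbers stand for higher permeability and lower numbers for lower permeability), compound 1 gives 11 10^-6 cm/s and compound 2 gives 16 10^-6 cm/s; these two values sit within the usual scatter of each other, so no order between them can be read. Compound 3 in this assay reaches only < 1 10^-6 cm/s, which is a limit of < 1 10^-6 cm/s in this assay, at which 1 of the 3 values shown sits, and not a number.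

Compound 4 `Cn1cc(C(=O)Nc2ccc(-c3cccnc3)c(C(F)(F)F)c2)c(=O)c2ccccc21` differs from compound 1 in one place: pyridin-3-yl in place of pyridin-2-yl on an aromatic carbon. Among the measured compounds shown here, no measured pair shows this kind of change, so the size of the step is open. The expectation for this assay is a small downward step, if any, staying within the scatter: compound 4 is estimated at 7 10^-6 cm/s (range 3 10^-6 cm/s to 15 10^-6 cm/s), meaning a step of a 1.6-fold lower number from compound 1 to compound 4 (0.20 log units; within the scatter).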

Compound 4, apparent permeability in the LLC-PK1 assay: 18 10^-6 cm/s
Compound 4: the middle estimate sits 2.6-fold (0.41 log units) below what was measured, outside the stated range (above it).
By their numbers in the LLC-PK1 assay, from the lowest: compounds 1, 2 and 4 (each within the scatter of the next). At a limit, below all of these: compound 3.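

In the LLC-PK1 assay, pyridin-3-yl in place of pyridin-2-yl at this position gives a 1.6-fold higher number from compound 1 to compound 4 (0.21 log units; within the scatter), so the two attachments cannot be told apart on this read-out. In a physicochemical assay for solubility, in simulated intestinal fluid, at pH 7.4 (on this read-out lower numbers stand for lower solubility and higher numbers for higher solubility), compound 1 gives 5.2 ug/mL and compound 4 gives 6.7 ug/mL, again values within the usual scatter of each other. Nothing measured here bears on a cause for either result.

On these data alone, whether an amine or a carboxylic acid on this aromatic carbon would leave both read-outs similarly unchanged stays open.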